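The compounds below may be only part of what the source reports. "The series", "measured", "known", "first", "only" and "open" are said of these compounds alone.

Among the compounds with values here, in an in vitro ADME assay on microsomes from liver (Rattus norvegicus) for metabolic stability, read by LC-MS, using NADPH, tested at 1 uM (on this read-out higher numbers stand for a longer-lived compound and lower numbers for a shorter-lived compound), compound 1 `O=C1CN(Cc2ccc(-c3ccc(F)c(CN4CCCCC4)n3)cc2)C(=O)N1CC1CC1` gives 0.2 h and compound 2 `CCN1C(=O)CN(Cc2ccc(-c3ccc(F)c(CN4CCCCC4)n3)cc2)C1=O` gives 0.517 h, which makes compound 2 the higher of the two numbers so far. The next structure is compound 3 `O=C1CN(Cc2ccc(-c3ccc(F)c(CN4CCCCC4)n3)cc2)C(=O)N1CC1CCC1`, and it differs from compound 2 in one place: cyclobutyl in place of methyl on a saturated chain carbon bound to an amide-type nitrogen in a ring. Here cyclobutyl stands in place of methyl on a saturated chain carbon bound to an amide-type nitrogen in a ring. Within the data shown here, only one measured step bears on this change: a 2.6-fold higher number from compound 1 to compound 2 (0.41 log units; beyond the scatter), a modest step in which methyl replaced cyclopropyl at that same place. Compound 3 goes the opposite way, back to a carbon ring, though no four-membered ring has been measured yet. A modest fall in this assay is therefore expected, and the estimated step is a 2.7-fold lower number from compound 2 to compound 3 (0.43 log units; beyond the scatter). For compound 3 the estimated half-life is 0.19 h, with an expected range from 0.09 h to 0.42 h.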

Compound 3, half-life: 0.0833 h
Compound 3: the middle estimate sits 2.3-fold (0.36 log units) above what was measured; measured number below the stated range.
By their numbers in this assay, from the lowest: compound 3; then compound 1; then compound 2.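

At this position in this assay, a larger group does not simply restore what cyclopropyl gave: cyclobutyl in place of methyl gives the lowest number of the three compounds (a 6.2-fold lower number from compound 2 to compound 3 (0.79 log units; beyond the scatter)). Ring size also matters. The two carbon rings are not interchangeable here (a 2.4-fold lower number from compound 1 to compound 3 (0.38 log units; beyond the scatter)), and among these three compounds the half-life shortens from methyl to cyclopropyl to cyclobutyl, with none going against that order. No measurement shown explains why these groups rank this way.

Three groups cannot show whether the order depends on ring size, on the number of carbons or on something else. An open-chain group such as propyl, a larger cyclopentyl ring or a ring containing oxygen, such as oxetanyl, could help separate these possibilities.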